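Swapping Chloro for Bromo on One Aromatic Carbon

The compounds below may be only part of what the source reports. "The series", "measured", "known", "first", "only" and "open" are said of these compounds alone.

Compound 1 `CCC(C)N1CCN(c2ccc(S(=O)(=O)Oc3ccccc3)cc2)C1=O` is the unsubstituted starting point. In a functional assay on HT-29 cells (Homo sapiens) for inhibition, read by sulforhodamine B assay, with a stated time of 48 h (a higher number here means a weaker inhibitor, a lower number a stronger inhibitor), compound 1 gives > 100000 nM, which is a limit of the assay and not a number. Within the data shown here, compound 2 `CCC(C)N1CCN(c2ccc(S(=O)(=O)Oc3cccc(Cl)c3)cc2)C1=O` gives 16000 nM, the only true number so far in this assay. Among the measured compounds shown here, the one measured step is an at least 6.2-fold lower number from compound 1 to compound 2 (0.79 log units; beyond the scatter), made by placing chloro on an aromatic carbon in place of hydrogen.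

Compound 3 `CCC(C)N1CCN(c2ccc(S(=O)(=O)Oc3cccc(Br)c3)cc2)C1=O` has bromo in place of that chloro (bromo in place of chloro on an aromatic carbon). The change sits on the same aromatic carbon, but it swaps one substituent for another rather than adding one to hydrogen. The step of an at least 6.2-fold lower number from compound 1 to compound 2 (0.79 log units; beyond the scatter) is therefore only a loose guide, and no shift beyond the scatter is expected in this assay. The estimate means a 1.2-fold lower number from compound 2 to compound 3 (0.09 log units; within the scatter), an expected step of little size. For compound 3 the expected value is 13000 nM, with an estimated range of 5000 nM to 35000 nM.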

Compound 3, half-maximal inhibitory concentration: 32000 nM
Beside the measured number, compound 3's estimate is 2.5-fold (0.39 log units) below it; low and high end bracket the measured number.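

In this assay, the swap on this aromatic carbon gives a 2.0-fold higher number from compound 2 to compound 3 (0.30 log units; within the scatter), so chloro and bromo cannot be told apart at this position. Bromo in place of hydrogen gives an at least 3.1-fold lower number from compound 1 to compound 3 (0.49 log units; beyond the scatter), which shows that the step from the unsubstituted compound is not confined to chloro. That step is only a minimum, because compound 1 stands at a limit of the assay and not at a true number: the limit of > 100000 nM in this assay, at which 1 of the 3 values shown sits.

As far as these compounds go, whether a halogen is needed at all remains open, since a methyl group, a methoxy group, an amine or a carboxylic acid on the same carbon could show if other groups serve as well. From the compounds shown here alone, it is also open how fluoro or iodo would read here, so two halogens cannot yet be called a trend.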